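Benzyl ester to free acid on the shared core

This account rests on a few compounds, and the source may have more. Where it says the series, first, only, none or still open, it means among the compounds named here.

Three compounds share one core and were tested in a functional assay on the whole organism (Tail, strain ICR) with Mus musculus as the target, in the tail flick test, with a stated time of 30 min, at a dose of 12.5 umol/kg by the oral route; on this read-out higher numbers stand for a stronger effect at the one dose given and lower numbers for a weaker effect. Compound 1 `NCCCC[C@H](NC(=O)CN(c1nc(Cl)nc2[nH]cnc12)C1CC1)C(=O)OCc1ccccc1` gives 18.5%, the highest of the three numbers, although its gaps to compound 3 `CC(C)C[C@H](NC(=O)CN(c1nc(Cl)nc2[nH]cnc12)C1CC1)C(=O)O`, which gives 16%, and to compound 2 `O=C(CN(c1nc(Cl)nc2[nH]cnc12)C1CC1)NCC(=O)OCc1ccccc1`, which gives 11.3%, both lie within the scatter. Within the data shown here, the one measured step, a number 7.2 percentage points lower from compound 1 to compound 2 (within the scatter), changes a side chain rather than the ester and so does not bear directly on the change considered here. Compound 4 `NCCCC[C@H](NC(=O)CN(c1nc(Cl)nc2[nH]cnc12)C1CC1)C(=O)O` differs from compound 1 by hydrogen in place of benzyl on an oxygen next to a carbonyl group. Among the measured compounds shown here, no measured pair isolates this change; compound 3, which carries a carboxy group, shows only that an acid on this core can give a number close to that of compound 1. The expected step is a number 3.5 percentage points lower from compound 1 to compound 4 (within the scatter), within the scatter. Compound 4 is therefore estimated at 15%, between 5% and 26%.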

Compound 4, a percentage reported as activity, at one dose (the size of the read-out at that dose, not a potency): 16.3%
Beside the measured number, compound 4's estimate is 1.3 percentage points below it; the range from low to high includes it.
By their numbers in this assay, from the lowest: compounds 2, 3, 4 and 1 (each within the scatter of the next).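

Removing the benzyl group from the ester, a step of a number 2.2 percentage points lower from compound 1 to compound 4 (within the scatter) in this assay, leaves the number within the usual scatter, so at this dose the benzyl ester is not needed for the effect seen. Among the free acids, the step of a number 0.3 percentage points higher from compound 3 to compound 4 (within the scatter) is also within the scatter, so the 3-aminopropyl and isopropyl groups cannot be told apart here. No evidence is available to explain either result.

Still open, on these data alone, is whether a methyl ester or a primary amide at this place would move the number beyond the scatter.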